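This account rests on a few compounds, and the source may have more. Where it says the series, first, only, none or still open, it means among the compounds named here.

Compound 3 `CC[C@H](NC(C)=O)c1cc(Cl)ccc1C1CCN(C(=O)[C@H]2CN(C(C)(C)C)C[C@@H]2c2ccc(C(F)(F)F)cc2F)CC1` gives 9.8 nM in an assay on CHO cells for displacement of a labelled ligand from Melanocortin receptor 4 (Homo sapiens) (on this read-out lower numbers stand for stronger inhibition and higher numbers for weaker inhibition), the lowest of the three numbers recorded; compound 1 `CC[C@H](NC(C)=O)c1cc(Cl)ccc1C1CCN(C(=O)[C@@H]2CN(C(C)(C)C)C[C@H]2c2ccc(Cl)cc2Cl)CC1` gives 17.9 nM, and compound 2 `CC[C@H](NC(C)=O)c1cc(Cl)ccc1C1CCN(C(=O)[C@@H]2CN(C(C)(C)C)C[C@H]2c2ccc(F)cc2Cl)CC1` gives 216 nM. Among the compounds with values here, the only single-point step among them, a 12-fold higher number from compound 1 to compound 2 (1.08 log units; beyond the scatter), concerns an aryl substituent and does not touch configuration. Compound 4 `CC[C@H](NC(C)=O)c1cc(Cl)ccc1C1CCN(C(=O)[C@@H]2CN(C(C)(C)C)C[C@H]2c2ccc(C(F)(F)F)cc2F)CC1` differs from compound 3 as follows: the two compounds have the same atoms and bonds and differ only in configuration as drawn: 2 of 3 stereo elements differ; a stereocentre at a saturated ring carbon is drawn R in compound 3 and S in compound 4; a stereocentre at a saturated ring carbon is drawn S in compound 3 and R in compound 4. Within the data shown here, no measured pair bears directly on such an inversion, so the direction of any step is uncertain; compound 1, which shares the drawn configuration of compound 4, still gives a low number. Compound 4 is therefore expected to show a 3.1-fold higher number from compound 3 to compound 4 (0.49 log units; beyond the scatter), giving an estimate of 30 nM with a range from 5 nM to 300 nM.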

Compound 4, half-maximal inhibitory concentration: 22.7 nM
Beside the measured number, compound 4's estimate is 1.3-fold (0.12 log units) above it, and the stated range covers the measured number.
By their numbers in this assay, from the lowest: compounds 3, 1 and 4 (each within the scatter of the next, the first and the last beyond it); then compound 2.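

In this assay, a 2.3-fold higher number from compound 3 to compound 4 (0.36 log units; beyond the scatter) gives the first reading of configuration at the two saturated ring carbons, and this modest step can be laid to configuration alone: the fact that compounds 3 and 4 differ only in the configuration as drawn

With that configuration held, the 2-fluoro-4-(trifluoromethyl)phenyl group gives a 9.5-fold lower number from compound 2 to compound 4 (0.98 log units; beyond the scatter) against the 2-chloro-4-fluorophenyl group, but a 1.3-fold higher number from compound 1 to compound 4 (0.10 log units; within the scatter) against the 2,4-dichlorophenyl group.

On these data alone, it remains open whether inverting one ring carbon alone, or inverting both with the 2,4-dichlorophenyl group in place, gives a similar step. As far as these compounds go, the effect of a carboxylic acid or an amine in place of the trifluoromethyl group also remains open.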